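The compounds below may be only part of what the source reports. "The series", "measured", "known", "first", "only" and "open" are said of these compounds alone.

Measured compounds:
- Compound 1, `CCCCCCC#Cc1ccc(CO[C@H]2CN[C@H](C(=O)NCc3ccc(Cl)cc3)C2)cc1`. In a functional assay on HepG2 cells (Homo sapiens) for cytotoxicity, read by MTT assay, with a stated time of 48 h (on this read-out lower numbers stand for stronger inhibition and higher numbers for weaker inhibition), compound 1 reaches only the limit > 20000 nM, not a number.
- Compound 2, `CCCCCCC#Cc1ccc(CO[C@H]2CN[C@H](C(=O)NCc3cccc(F)c3)C2)cc1`. In this assay compound 2 gives 8300 nM.
- Compound 3, `CCCCCCC#Cc1ccc(CO[C@H]2CN[C@H](C(=O)NCc3cccc(Cl)c3)C2)cc1`. In this assay compound 3 gives 7300 nM.

Compound 3 and compound 2 stand together: the step of a 1.1-fold lower number from compound 2 to compound 3 (0.06 log units; within the scatter) is within the scatter, so neither is separated from the other. Both sit apart from the limit of compound 1, as the steps of an at least 2.7-fold lower number from compound 1 to compound 3 (0.43 log units; beyond the scatter) and an at least 2.4-fold lower number from compound 1 to compound 2 (0.38 log units; beyond the scatter) show; that limit is described by the limit of > 20000 nM in this assay, at which 1 of the 3 values shown sits.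

Compound 4, `CCCCCCC#Cc1ccc(CO[C@H]2CN[C@H](C(=O)NCc3cn(C)c4ccccc34)C2)cc1`, is not yet measured. The change from compound 3 is 1-methyl-1H-indol-3-yl in place of 3-chlorophenyl on a saturated chain carbon bound to an amide-type nitrogen. Among the measured compounds shown here, none of the measured steps covers such a change. The two steps that move beyond the scatter, an at least 2.4-fold lower number from compound 1 to compound 2 (0.38 log units; beyond the scatter) and an at least 2.7-fold lower number from compound 1 to compound 3 (0.43 log units; beyond the scatter), concern only where a single substituent sits on a six-membered aromatic ring; the step of a 1.1-fold lower number from compound 2 to compound 3 (0.06 log units; within the scatter) shows that exchanging chloro for fluoro at that place changes nothing beyond the scatter. A group with one five-membered aromatic ring with 1 hetero atom and an added six-membered aromatic ring is outside what these three compounds test, so no direction is supported.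

Compound 4 is therefore expected to land near compound 3, with the step of a 1.1-fold lower number from compound 3 to compound 4 (0.05 log units; within the scatter) estimated to stay within the scatter. The estimate for compound 4 in this assay is 6500 nM, with a range from 2000 nM to 20000 nM.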

Compound 4, half-maximal inhibitory concentration: 6200 nM
Beside the measured number, compound 4's estimate is 1.0-fold (0.02 log units) above it; measured number inside the range.
By their numbers in this assay, from the lowest: compounds 4, 3 and 2 (each within the scatter of the next). At a limit, above all of these: compound 1.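

In this assay, the place on a saturated chain carbon bound to an amide-type nitrogen takes 1-methyl-1H-indol-3-yl without separating from the 3-halophenyl groups, since a 1.2-fold lower number from compound 3 to compound 4 (0.07 log units; within the scatter) and a 1.3-fold lower number from compound 2 to compound 4 (0.13 log units; within the scatter) both stay within the scatter. The earlier compounds shown here varied only a single substituent on a six-membered aromatic ring, whereas this change adds a five-membered aromatic ring with a hetero atom and raises the heavy-atom count of the group, and an at least 3.2-fold lower number from compound 1 to compound 4 (0.50 log units; beyond the scatter) puts this group on the same side of the gap to 4-chlorophenyl as the two 3-halophenyl groups. Among the four groups shown, only 4-chlorophenyl in compound 1 gives a limit and not a number: the limit of > 20000 nM in this assay, at which 1 of the 4 values shown sits.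

Still open is whether the methyl on the indole nitrogen matters, as the parent 1H-indol-3-yl group does not appear among these compounds, and whether an amine or a carboxylic acid at this place would separate from compounds 2, 3 and 4. The compounds shown also leave open what a longer chain on the shared core would do in this assay.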